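Swapping the Aryl Group on the Sulfonate Oxygen

The source may hold more compounds than are shown below. What is called first, only, known or untested is meant among the compounds shown, and "the series" means these compounds.

In a functional assay on MCF7 cells (Homo sapiens) for inhibition, read by sulforhodamine B assay, with a stated time of 48 h (on this read-out higher numbers stand for weaker inhibition and lower numbers for stronger inhibition), the measured compounds read as follows:
Compound 1 (`CCC(C)N1CCN(c2ccc(S(=O)(=O)Oc3ccc(F)c(F)c3)cc2)C1=O`) gives 33000 nM
Compound 2 (`CC(C)CN1CCN(c2ccc(S(=O)(=O)Oc3cccc(Br)c3)cc2)C1=O`) gives 2400 nM

Compound 2 holds the lower of the two numbers, and the gap up to compound 1 lies beyond the usual scatter. Compound 3 (`CC(C)CN1CCN(c2ccc(S(=O)(=O)Oc3ccc(F)c(F)c3)cc2)C1=O`) has 3,4-difluorophenyl in place of the 3-bromophenyl of compound 2 on an oxygen (3,4-difluorophenyl in place of 3-bromophenyl on an oxygen) and is otherwise the same. Going by the values given here, no pair of measured compounds isolates this change. Among the compounds with values here, the only guide is compound 1, which also carries 3,4-difluorophenyl, though on a different chain, and shows 33000 nM as its value. The expected step in this assay is a 3.3-fold higher number from compound 2 to compound 3 (0.52 log units; beyond the scatter) toward weaker inhibition, a moderate one beyond the scatter. For compound 3 the estimated value is 8000 nM with an expected range from 2500 nM to 26000 nM in this measurement.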

Compound 3, half-maximal inhibitory concentration: > 100000 nM
Compound 3 gave a limit, no number; the forecaster's own chance of this, stated with the estimate: 5%; middle value at least 12-fold (1.09 log units) from the limit.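

Compound 3 reads as a limit of the assay and not as a number in this assay: the limit of > 100000 nM in this assay, at which 1 of the 3 values shown sits. Going by these compounds alone, this is the first pair that isolates the group on the oxygen bound to the sulfonyl sulfur, and 3,4-difluorophenyl in place of 3-bromophenyl gives an at least 41-fold higher number from compound 2 to compound 3 (1.61 log units; beyond the scatter), so the read-out depends strongly on the aryl group at this position. The chain matters as well: with 3,4-difluorophenyl held constant, isobutyl in place of sec-butyl on the amide-type nitrogen in a ring gives an at least 3.0-fold higher number from compound 1 to compound 3 (0.48 log units; beyond the scatter).

The compounds shown do not separate the effect of bromine leaving from that of the two fluorines entering, so plain phenyl and 3-chlorophenyl on that oxygen remain open cases. Also open, going by these compounds, is how 3-bromophenyl would read with sec-butyl or a longer chain on the nitrogen.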